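Swapping a bromopropoxy chain for an allyloxy chain

The source may hold more compounds than are shown below. What is called first, only, known or untested is meant among the compounds shown, and "the series" means these compounds.

In a functional assay on mitochondria (Cricetulus griseus) for inhibition of Monoamine oxidase (Homo sapiens), tested at 9 uM (a higher number here means a stronger effect of the compound at the concentration tested, a lower number a weaker effect), compound 3 `O=c1c(-c2ccc(O)cc2)coc2cc(OCCCBr)ccc12` gives 100%, and compound 1 `CCOc1ccc2c(=O)c(-c3ccc(O)cc3)coc2c1` gives 100%; these two stand level and together the highest of three numbers, while compound 2 `O=c1c(-c2ccc(O)cc2)coc2cc(OCCCCCCBr)ccc12` gives 95.7%. Every step among them stays within the scatter: a number 4.3 percentage points lower from compound 1 to compound 2 (within the scatter), no change at the digits printed from compound 1 to compound 3 (within the scatter) and a number 4.3 percentage points higher from compound 2 to compound 3 (within the scatter). Compound 4 `C=CCOc1ccc2c(=O)c(-c3ccc(O)cc3)coc2c1` differs from compound 3 by vinyl in place of 2-bromoethyl on a saturated chain carbon bound to an oxygen on an aromatic ring. The three measured steps all alter the same chain on the oxygen on the aromatic ring without moving the read-out beyond the scatter, so compound 4 is expected to behave alike, with a step of a number 2 percentage points lower from compound 3 to compound 4 (within the scatter) in this assay and no change beyond the scatter. Compound 4 is therefore estimated at 98%, within 88% to 100%.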

Compound 4, a percentage reported as inhibition, at one concentration (the size of the read-out at that concentration, not a potency): 100%
The estimate for compound 4 lay 2 percentage points below the measured number; measured number inside the range.
By their numbers in this assay, from the lowest: compounds 2, 1, 3 and 4 (each within the scatter of the next).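

In this assay, the vinyl end of the allyl chain brings a double bond outside aromatic rings to this place, and the read-out stays within the scatter of every earlier chain (no change at the digits printed from compound 3 to compound 4 (within the scatter); a number 4.3 percentage points higher from compound 2 to compound 4 (within the scatter); no change at the digits printed from compound 1 to compound 4 (within the scatter)). The chain on the oxygen on an aromatic ring therefore tolerates an unsaturated end as well as the saturated chains, with or without bromine. Nothing measured here bears on why this is so.

On these data alone, whether an amine or a carboxylic acid at the end of this chain would hold the read-out remains open. So does whether these compounds would separate at a lower concentration, since a single concentration gives no potency.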